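Changing the aryl group of compound 1

The source may report more compounds than this note shows. Statements on the series, on what has been measured and on what is new or still open speak of the compounds shown alone.

Measured so far:
- compound 1 `OC[C@H]1O[C@@H](n2cnc3c(NCc4ccc(Cl)cc4)ncnc32)[C@H](O)[C@@H]1O`: > 166000 nM
- compound 2 `COc1cc(CNc2ncnc3c2ncn3[C@@H]2O[C@H](CO)[C@@H](O)[C@H]2O)cc(OC)c1`: "not determined" (no result reported)

In a functional assay on B16 cells (Mus musculus) for antiproliferative activity, with a stated time of 72 h (on this read-out lower numbers stand for stronger inhibition and higher numbers for weaker inhibition), compound 1 gives > 166000 nM, which is a limit of the assay rather than a number; it sits at the limit of > 166000 nM in this assay, at which 1 of the 2 values shown sits. Compound 2 has no result in this assay. Compound 3 `COc1cccc(CNc2ncnc3c2ncn3[C@@H]2O[C@H](CO)[C@@H](O)[C@H]2O)c1O` differs from compound 1 in one place: 2-hydroxy-3-methoxyphenyl in place of 4-chlorophenyl on a saturated chain carbon bound to a nitrogen on an aromatic ring. Within the data shown here, no step between measured compounds is available, and from a limit the direction of a step cannot be told. The step of an at least 1.1-fold lower number from compound 1 to compound 3 (0.04 log units; that floor lies within the scatter) is expected to stay within the scatter, so compound 3 is expected to give 150000 nM in this assay, between 30000 nM and 600000 nM.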

Compound 3, half-maximal inhibitory concentration: > 166000 nM
Compound 3: only a limit was reported; the forecaster's own chance of this, stated with the estimate: 70%; at least 1.1-fold (0.04 log units) between middle value and limit.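

In this assay compound 3 gives > 166000 nM as a limit, not a number. Among these compounds, compound 1 also stands at a limit, so no step between compound 1 and compound 3 can be read. On these data alone, whether 4-chlorophenyl or 2-hydroxy-3-methoxyphenyl gives the stronger inhibition stays open.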